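Replacing Ethyl with Fluoro on a Ring Carbon

The compounds below may be only part of what the source reports. "The series", "measured", "known", "first", "only" and "open" are said of these compounds alone.

Measured in an ADME assay on microsomes from liver (Mus musculus) for metabolic stability, with a stated time of 10 min (a higher number here means that more of the compound is left, a lower number that less of the compound is left), so far:
compound 1 (`O=C(O)C12CCC(C(=O)N3CC[C@](c4ccc(C(F)(C(F)(F)F)C(F)(F)F)cc4)(S(=O)(=O)c4ccc(F)cc4)C3)(CC1)C2`) gives "not determined" (no result reported)
compound 2 (`CCC1(C(=O)N2CC[C@](c3ccc(C(F)(C(F)(F)F)C(F)(F)F)cc3)(S(=O)(=O)c3ccc(F)cc3)C2)CCS(=O)(=O)CC1`) gives 0%

Going by the values given here, compound 1 has no result, so compound 2 at 0% holds the only number. None of compound 2 is left at the end of the test, which gives a low starting point.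

Compound 3 (`O=C(N1CC[C@](c2ccc(C(F)(C(F)(F)F)C(F)(F)F)cc2)(S(=O)(=O)c2ccc(F)cc2)C1)C1(F)CCS(=O)(=O)CC1`) keeps the shared core and changes one group (fluoro in place of ethyl on a saturated ring carbon). The new group stands three ring bonds from the ring sulfur.

Among the compounds with values here, no measured step exists to size this change, so any expectation is loose. Because compound 2 sits at 0% there is no room for a drop, and any change can only be upward. The expected change is a moderate rise (a number 15 percentage points higher from compound 2 to compound 3 (beyond the scatter)) in this assay with no change still possible. For compound 3 the estimated value is 15% with an expected range from 0% to 45% in this read-out.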

Compound 3, percent of the compound remaining: 90%
Estimate against measurement, compound 3: 75 percentage points below; the whole stated range lies below it.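

Swapping ethyl for fluoro on this saturated ring carbon produces a number 90 percentage points higher from compound 2 to compound 3 (beyond the scatter) in this assay. This shows that the group at this one place has a very strong hold on the read-out: with the rest of the shared core unchanged, a single small replacement moves the result from one end of the scale almost to the other. No measurement shown gives a reason for the size of this step.

The compounds shown leave open whether fluoro is unusual at this ring carbon, or whether another replacement for ethyl, such as a methyl, a hydroxyl or a nitrile, would give a similar result. They also leave open whether the same swap would have as large an effect on a ring without the sulfur.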